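This account rests on a few compounds, and the source may have more. Where it says the series, first, only, none or still open, it means among the compounds named here.

Compound 1 `CCCN(CC#Cc1cc2ncnc(Nc3ccc(OCc4cccc(F)c4)c(Cl)c3)c2s1)CCC` and compound 2 `CN(C)CC#Cc1cc2ncnc(Nc3ccc(OCc4cccc(F)c4)c(Cl)c3)c2s1` are built on one core, while compound 3 `CCCN(CC#Cc1cc2c(Nc3ccc(OCc4cccc(F)c4)c(Cl)c3)ncnc2s1)CCC` and compound 4 `CN(C)CC#Cc1cc2c(Nc3ccc(OCc4cccc(F)c4)c(Cl)c3)ncnc2s1` are built on another. Compound 3 contains the same atoms as compound 1, joined differently, and the difference between the two cores is not broken down here. The compounds were examined in an ADME assay on NIH3T3 cells (Mus musculus) for cytotoxicity; on this read-out higher numbers stand for lower toxicity in this test and lower numbers for higher toxicity in this test. In this assay compound 1 gives only a limit of the assay, > 50 uM. In this assay compound 2 likewise gives only a limit of the assay, > 50 uM. Among the measured compounds shown here, compound 3 is the one compound with an actual number: in this assay compound 3 gives 2.2 uM.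

One structural change appears twice in this set. Between the first pair it is dimethylamino in place of dipropylamino on a saturated chain carbon bound to a triple-bonded carbon. Its step, a step that the two limits leave unreadable from compound 1 to compound 2, cannot be sized because both compounds sit at the limit of > 50 uM in this assay, at which 2 of the 3 values shown sit. The same change is made again from compound 3 to compound 4, namely (dimethylamino in place of dipropylamino on a saturated chain carbon bound to a triple-bonded carbon), at the same place as before.

Since the measured pair leaves the step unreadable, the expectation for compound 4 rests on compound 3 and its 2.2 uM, with wide room in either direction. The step from compound 3 to compound 4 is estimated at a 1.8-fold higher number from compound 3 to compound 4 (0.26 log units; within the scatter). Compound 4 is expected to give about 4 uM in this assay, with a likely range from 1.2 uM to 25 uM.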

Compound 4, half-maximal toxic concentration: 41 uM
Beside the measured number, compound 4's estimate is 10-fold (1.01 log units) below it; the measured number lies above the stated range.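

On the core of compound 3, putting dimethylamino in place of dipropylamino goes with a 19-fold higher number from compound 3 to compound 4 (1.27 log units; beyond the scatter) in this assay, so on this core the change is large and lies beyond the scatter. On the other core the same change cannot be sized, because compound 1 and compound 2 both give only a limit of the assay: the limit of > 50 uM in this assay, at which 2 of the 4 values shown sit. The change has therefore been read on one core only: the limits neither show that a step of this size carries over to the other core nor show that it fails to, and the result gives no reason why dimethylamino goes with the higher number.

The compounds shown leave open how the number moves with other amines on a saturated chain carbon bound to a triple-bonded carbon, such as diethylamino or morpholine, and so whether the step on the core of compound 3 follows the length of the chains on the nitrogen or belongs to dipropylamino alone. They also leave open whether any amine on the core of compound 1, for example dibutylamino with its longer chains, would give an actual number against which the change could be sized on that core.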